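The source may report more compounds than this note shows. Statements on the series, on what has been measured and on what is new or still open speak of the compounds shown alone.

Compound 1 `O=C1C=C(Nc2ccccc2)C(=O)c2c1nc1n2[C@H]2OC[C@@H](O)[C@H]2OC1` is tested in a functional assay on MCF7 cells (Homo sapiens) for inhibition, read by sulforhodamine B assay; a lower number here means a stronger inhibitor, a higher number a weaker inhibitor. In this assay compound 1 gives only a limit, > 4000 nM. Compound 2 `O=C1C(Nc2ccccc2)=CC(=O)c2c1nc1n2[C@H]2OC[C@@H](O)[C@H]2OC1` in this assay likewise gives a limit, > 4000 nM. Compound 3 `O=C1C(Nc2ccc(C(F)(F)F)cc2)=CC(=O)c2c1nc1n2[C@H]2OC[C@@H](O)[C@H]2OC1` in this assay gives a limit too, > 4000 nM. So all three measured compounds share one position: the limit of > 4000 nM in this assay, at which 3 of the 3 values shown sit. Among the compounds with values here, the only step between two measured compounds that differ in a single place, a step that the two limits leave unreadable from compound 2 to compound 3, therefore offers no readable size, and it concerns a trifluoromethyl on the aromatic ring rather than the change considered here.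

Compound 4 `O=C1C=C(N2CCCC2)C(=O)c2c1nc1n2[C@H]2OC[C@@H](O)[C@H]2OC1` differs from compound 1 in one place: pyrrolidin-1-yl in place of anilino on a double-bonded ring carbon. Within the data shown here, no measured step bears on this change, and no measured compound gives a number rather than a limit. The expectation for compound 4 therefore rests only on the shared limit, and the step that the limit leaves unreadable from compound 1 to compound 4 is estimated to leave compound 4 near or beyond that limit. Compound 4 is expected to give about 7000 nM in this assay, within a range from 2000 nM to 25000 nM.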

Compound 4, half-maximal inhibitory concentration: > 16000 nM
Compound 4: a limit, no number; the forecaster's own chance of this, stated with the estimate: 75%; at least 2.2-fold (0.35 log units) between middle value and limit.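

Compound 1 and compound 4 each give only a limit in this assay, so the step from anilino to pyrrolidin-1-yl cannot be read. The compounds shown leave open how strongly any of them inhibits and whether this change on the shared core alters inhibition at all.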